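The source may hold more compounds than are shown below. What is called first, only, known or untested is meant among the compounds shown, and "the series" means these compounds.

Compound 2 `CC1CCC(Sc2nc(C(F)(F)F)ccc2CNC(=O)C(C)c2ccc(NS(C)(=O)=O)c(F)c2)CC1` stands as the lower of the two numbers measured in an assay on CHO-K1 cells for antagonist activity at transient receptor potential cation channel subfamily V member 1 (Homo sapiens), read by FLIPR (a lower number here means a stronger inhibitor, a higher number a weaker inhibitor), at 0.5 nM. Compound 1 `COC(=O)CCSc1nc(C(F)(F)F)ccc1CNC(=O)C(C)c1ccc(NS(C)(=O)=O)c(F)c1` gives 48.2 nM in this assay. Going by the values given here, the only step between measured compounds, a 96-fold lower number from compound 1 to compound 2 (1.98 log units; beyond the scatter), shows how strongly the group on the sulfur can move the number. Compound 3 `Cc1ccc(CSc2nc(C(F)(F)F)ccc2CNC(=O)C(C)c2ccc(NS(C)(=O)=O)c(F)c2)cc1` differs from compound 2 in one place: 4-methylbenzyl in place of 4-methylcyclohexyl on a sulfur. Among the compounds with values here, only the step from compound 1 to compound 2 bears on this change, since it concerns the same sulfur substituent, but that step swapped an open chain for a ring, whereas here a six-membered non-aromatic ring of carbon only gives way to a six-membered aromatic ring with one more heavy atom, so a much smaller shift is expected. Compound 3 is estimated to give 1.5 nM in this assay, within 0.4 nM to 6 nM. The expected step is a 3.0-fold higher number from compound 2 to compound 3 (0.48 log units; beyond the scatter), modest and toward a higher number.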

Compound 3, inhibition constant: 3.2 nM
Compound 3: middle estimate off by 2.1-fold (0.33 log units), on the low side, within the range that was stated.
By their numbers in this assay, from the lowest: compound 2; then compound 3; then compound 1.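

In this assay, 4-methylbenzyl in place of 4-methylcyclohexyl on the sulfur gives a 6.4-fold higher number from compound 2 to compound 3 (0.81 log units; beyond the scatter) and so shows that the two ring-bearing groups are not interchangeable at this position. Compound 3 nevertheless keeps part of the gain over the open chain, with a 15-fold lower number from compound 1 to compound 3 (1.18 log units; beyond the scatter) set against the larger 96-fold lower number from compound 1 to compound 2 (1.98 log units; beyond the scatter) for the 4-methylcyclohexyl group. Nothing measured here explains why the 4-methylbenzyl group gives the higher number. The step from compound 2 to compound 3 changes the ring and adds a carbon between it and the sulfur, so the compounds shown cannot separate the two changes. They also leave open how a plain cyclohexyl, a 4-methylphenyl bound directly to the sulfur, or a piperidine ring carrying a ring amine would behave here.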